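This account rests on a few compounds, and the source may have more. Where it says the series, first, only, none or still open, it means among the compounds named here.

In a functional assay on A549 cells (Homo sapiens) for cytotoxicity, read by MTT assay, with a stated time of 72 h (on this read-out higher numbers stand for weaker inhibition and lower numbers for stronger inhibition), compound 2 `O=C(Nc1nnc(-c2ccc(O)c(O)c2)s1)c1ccc(Cl)cc1` gives 14600 nM and compound 1 `O=C(COc1ccccc1)Nc1nnc(-c2ccc(O)c(O)c2)s1` gives 21200 nM, so the two stand within the scatter of each other. Compound 3 `CC(=O)Nc1nnc(-c2ccc(O)c(O)c2)s1` differs from compound 2 by methyl in place of 4-chlorophenyl on a carbonyl carbon. Within the data shown here, the one measured step at this place is a 1.5-fold lower number from compound 1 to compound 2 (0.16 log units; within the scatter), 4-chlorophenyl in place of phenoxymethyl, and it lies within the scatter. Among the measured compounds shown here, no measured compound carries methyl here, so this guide is weak. The expected change in this assay is none beyond the scatter, with a 1.4-fold higher number from compound 2 to compound 3 (0.14 log units; within the scatter) as the estimated step. The estimated value for compound 3 is 20000 nM, with an expected range from 8000 nM to 50000 nM.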

Compound 3, half-maximal inhibitory concentration: 133000 nM
Compound 3: middle estimate off by 6.7-fold (0.82 log units), on the low side; the measured number lies above the stated range.
By their numbers in this assay, from the lowest: compounds 2 and 1 (each within the scatter of the next); then compound 3.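

Among these compounds, on the carbonyl carbon, methyl in place of 4-chlorophenyl gives a 9.1-fold higher number from compound 2 to compound 3 (0.96 log units; beyond the scatter) in this assay and is the first change here to pass beyond the scatter. Hydrogen in place of phenoxy on the saturated chain carbon bound to a carbonyl carbon gives a 6.3-fold higher number from compound 1 to compound 3 (0.80 log units; beyond the scatter) in the same read-out, so among these three compounds, methyl stands apart from both 4-chlorophenyl and phenoxymethyl. No evidence on the cause of this shift is available.

The compounds shown leave open whether an aromatic ring is needed at this place. A cyclohexyl group or a longer chain such as butyl would test this.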